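Replacing a trifluoromethylphenyl with a hydroxyphenyl at the ether

This account rests on a few compounds, and the source may have more. Where it says the series, first, only, none or still open, it means among the compounds named here.

Compound 3 `NCCCOc1ccc(CNc2nc3ccc(Oc4cccc(C(F)(F)F)c4)cc3s2)cc1` is a secondary amine bearing a propoxyamine chain on the benzyl ring and a 3-(trifluoromethyl)phenoxy group on the shared core. In an assay on cells for inhibition of Voltage-dependent T-type calcium channel subunit alpha-1H (Homo sapiens), read by FLIPR and calcium flux, with stated times of 600 s and 300 s (on this read-out lower numbers stand for stronger inhibition and higher numbers for weaker inhibition), compound 3 gives 171000 nM, which is the second highest of the three numbers measured. Compound 1 `CN(Cc1ccc(OCCCN)cc1)c1nc2ccc(Oc3ccc(F)cc3)cc2s1` gives 492000 nM in this assay, a higher number than that of compound 3 by more than the scatter, while compound 2 `CN(C)CCCOc1ccc(CN(C)c2nc3ccc(Oc4ccc(C(F)(F)F)cc4)cc3s2)cc1` gives 54000 nM, the lowest of the three, again separated from compound 3 by more than the scatter. Among the measured compounds shown here, no two measured compounds differ in only one place, so no single step can be read directly.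

Compound 4 `NCCCOc1ccc(CNc2nc3ccc(Oc4ccc(O)cc4)cc3s2)cc1` is compound 3 with one change: 4-hydroxyphenyl in place of 3-(trifluoromethyl)phenyl on an oxygen on an aromatic ring. For the measured compounds named here, with compounds 1 and 3 both far above compound 2, a weakening step is expected here, of the size a 1.9-fold higher number from compound 3 to compound 4 (0.27 log units; within the scatter), in the direction of a higher number, though the data give no matched pair to anchor it. Compound 4 is therefore estimated at 320000 nM in this assay, within a range from 110000 nM to 1000000 nM.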

Compound 4, half-maximal inhibitory concentration: 300000 nM
Compound 4: middle estimate off by 1.1-fold (0.03 log units), on the high side; low and high end bracket the measured number.
By their numbers in this assay, from the lowest: compound 2; then compounds 3, 4 and 1 (each within the scatter of the next, the first and the last beyond it).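

Among the compounds shown here, this is the first matched pair at this position, and in this assay it gives a 1.8-fold higher number from compound 3 to compound 4 (0.24 log units; within the scatter), a step within the usual scatter. Exchanging 3-(trifluoromethyl)phenyl for 4-hydroxyphenyl on an oxygen on an aromatic ring removes all the fluorine, moves the substituent's ring position and adds a hydrogen-bond donor and acceptor, yet the read-out does not separate the two compounds. Nothing available accounts for this result.

For the compounds shown here, the single step changes both the substituent and its ring position, so it leaves open what each contributes alone. It also leaves open whether an amine or a carboxylic acid in place of the hydroxyl on this phenyl ring would give a read-out that could be told apart from that of compound 4.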